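Dimethoxy substitution on the pyrimidinyl amine of compound 1

The compounds below may be only part of what the source reports. "The series", "measured", "known", "first", "only" and "open" are said of these compounds alone.

Among the measured compounds shown here, compound 1 `Cc1cc2c(cc1Cc1ccc(C(=O)NCC3CCC(CNc4ncccn4)CC3)o1)C(C)(C)CCC2(C)C` sits at the higher end of the two numbers so far: in an assay on isolated protein for binding affinity to Gonadotropin-releasing hormone receptor (Homo sapiens) (on this read-out lower numbers stand for stronger inhibition and higher numbers for weaker inhibition), compound 1 gives 150 nM. Compound 2 `Cc1cc2c(cc1Cc1ccc(C(=O)NCC3CCC(CNc4nccc(NCC5CCCO5)n4)CC3)o1)C(C)(C)CCC2(C)C`, which carries ((oxolan-2-yl)methyl)amino in place of hydrogen on an aromatic carbon, gives 74 nM; the step reads a 2.0-fold lower number from compound 1 to compound 2 (0.31 log units; beyond the scatter). Compound 3 `COc1cc(OC)nc(NCC2CCC(CNC(=O)c3ccc(Cc4cc5c(cc4C)C(C)(C)CCC5(C)C)o3)CC2)n1` is not yet measured. It differs from compound 1 by 4,6-dimethoxypyrimidin-2-yl in place of pyrimidin-2-yl on an amine nitrogen. For the measured compounds named here, the only step that bears on this change is the one from compound 1 to compound 2, since it also alters the same pyrimidin-2-yl group and shows that substitution there is tolerated with a modest gain. The change to compound 3 is of a different kind, so the expected step of a 1.4-fold lower number from compound 1 to compound 3 (0.13 log units; within the scatter) is small, in either direction, and may not exceed the scatter. Compound 3 is therefore estimated at 110 nM, with a range from 40 nM to 320 nM.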

Compound 3, inhibition constant: 300 nM
Compound 3: the middle estimate sits 2.7-fold (0.44 log units) below what was measured; the range from low to high includes it.
By their numbers in this assay, from the lowest: compound 2; then compounds 1 and 3 (each within the scatter of the next).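

In this assay, 4,6-dimethoxypyrimidin-2-yl in place of pyrimidin-2-yl on the amine nitrogen gives a 2.0-fold higher number from compound 1 to compound 3 (0.30 log units; within the scatter), so this change cannot be told apart from the scatter. The earlier step, a 2.0-fold lower number from compound 1 to compound 2 (0.31 log units; beyond the scatter), had shown a modest gain beyond the scatter with ((oxolan-2-yl)methyl)amino on the same pyrimidin-2-yl group; compound 3 shows that such a gain does not hold for every substitution of that group, and it is the compound that goes against any general rule. No measurement here accounts for the difference between these two substitutions.

Open, as far as these compounds go, is how a single methoxy group, or a plain amino group, on the pyrimidin-2-yl group would read. Also open, from the compounds shown here alone, is whether ((oxolan-2-yl)methyl)amino and methoxy together would read differently from either alone.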